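Swapping methoxy for fluoro on a biaryl amidine

The source may hold more compounds than are shown below. What is called first, only, known or untested is meant among the compounds shown, and "the series" means these compounds.

Compound 1, with the structure `COc1ccc(-c2ccc(-c3ccc(C(=N)N)cc3)s2)cc1`, is the starting point of this step, yet in a functional assay on K562 cells (Homo sapiens) for inhibition, read by sulforhodamine B assay, with a stated time of 48 h (on this read-out lower numbers stand for stronger inhibition of growth and higher numbers for weaker inhibition of growth), compound 1 is recorded as "not determined" (no result reported): no result was reported for it, so nothing can be said of where it stands. Within the data shown here, the only measured relative is compound 2, `N=C(N)c1ccc(-c2ccc(-c3cc(Cl)cc(Cl)c3)s2)cc1`, which in this assay gives 225 nM. The unmeasured compound 3, `N=C(N)c1ccc(-c2ccc(-c3ccc(F)cc3)s2)cc1`, differs from compound 1 by one change, (fluoro in place of methoxy on an aromatic carbon). Since compound 1 has no value, the size of the step from compound 1 to compound 3 in this assay cannot be judged from the numbers shown; the step is expected to be small, likely within the usual scatter, in no firm direction. Resting on the value of compound 2, compound 3 is expected to give roughly 350 nM in this assay, with an estimated range from 90 nM to 1400 nM.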

Compound 3, concentration for 50% growth inhibition: 268 nM
Compound 3: middle estimate off by 1.3-fold (0.12 log units), on the high side; the measured number falls inside the stated range.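

In this assay, among these compounds, compound 1 stands as "not determined" (no result reported), so no step from it to compound 3 can be read. From the compounds shown here alone, what swapping methoxy for fluoro does to growth inhibition therefore remains open. No measured property is available to explain the result for compound 3.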